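Ester to Morpholine Amide on Two Related Cores

The compounds below may be only part of what the source reports. "The series", "measured", "known", "first", "only" and "open" are said of these compounds alone.

Measured compounds in an assay on a protein complex for inhibition of CDK8/Cyclin C (Homo sapiens), with a stated time of 1 h, tested at 10 uM; on this read-out higher numbers stand for more inhibition at the one concentration tested (going by the name of the read-out) and lower numbers for less inhibition:
compound 1 `CCOC(=O)/C=C/c1ccncc1-c1ccc2c(cnn2C)c1`: 100%
compound 2 `Cn1ncc2cc(-c3cnccc3/C=C/C(=O)N3CCOCC3)ccc21`: 95%
compound 3 `CCOC(=O)/C=C/c1ccncc1-c1ccc2cc[nH]c2c1`: 104%

Compound 1 and compound 2 differ in one place, (morpholin-4-yl in place of ethoxy on a carbonyl carbon), and this assay records a number 5 percentage points lower from compound 1 to compound 2 (within the scatter). Compound 3 carries the ethoxycarbonyl side of compound 1 on a different core; the difference between the two cores is not broken down here, and the two values lie within the scatter of each other, as do those of compound 3 and compound 2.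

Compound 4 `O=C(/C=C/c1ccncc1-c1ccc2cc[nH]c2c1)N1CCOCC1` is built from compound 3 by morpholin-4-yl in place of ethoxy on a carbonyl carbon, the same change as that from compound 1 to compound 2, made at the same kind of place. Because the earlier step of a number 5 percentage points lower from compound 1 to compound 2 (within the scatter) stayed within the scatter, compound 4 is expected to stay close to compound 3 as well. Compound 4 is therefore estimated at 99% in this assay. The expected range for compound 4 runs from 88% to 107%. The step this estimate implies is a number 5 percentage points lower from compound 3 to compound 4 (within the scatter).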

Compound 4, a percentage reported as inhibition, at one concentration (the size of the read-out at that concentration, not a potency): 102%
For compound 4 the middle estimate is 3 percentage points below the measured one; low and high end bracket the measured number.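

In this assay, morpholin-4-yl in place of ethoxy on a carbonyl carbon gives a number 2 percentage points lower from compound 3 to compound 4 (within the scatter) on the second core, and the two readings of the change do not differ: the same change on two cores in this assay, a number 5 percentage points lower (within the scatter) from compound 1 to compound 2 and a number 2 percentage points lower (within the scatter) from compound 3 to compound 4, 3 percentage points apart, within the scatter of two such steps.
Within this pair of cores, the change therefore carries over without a discernible difference. The read-out gives the size of the inhibition at one concentration rather than a potency, so this does not show that the change leaves potency untouched on either core, and two cores cannot speak for the whole series.

The compounds shown leave open how an open-chain amine such as diethylamino, or a carboxylic acid in place of the ester, would read on these cores. They also leave open whether the same holds for a piperazine in place of the morpholine.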